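The compounds below may be only part of what the source reports. "The series", "measured", "known", "first", "only" and "open" are said of these compounds alone.

In a functional assay on DU-145 cells (Homo sapiens) for cytotoxicity, read by sulforhodamine B assay, with a stated time of 2 days, tested at 100 uM (a higher number here means more inhibition at the concentration tested (going by the name of the read-out), a lower number less inhibition), compound 1 `O=C(Nn1c(-c2cccc([N+](=O)[O-])c2)nc2c(-c3ccc(Cl)cc3)n[nH]c2c1=O)c1cccnc1` gives 31%, the second highest of the three numbers. Compound 3 `O=C(Nn1c(-c2cccc([N+](=O)[O-])c2)nc2c(-c3cccs3)n[nH]c2c1=O)c1cccnc1` gives 32.8%, and the step of a number 1.8 percentage points higher from compound 1 to compound 3 (within the scatter) stays within the scatter. Compound 2 `O=C(Nn1c(-c2cccc([N+](=O)[O-])c2)nc2c(-c3ccco3)n[nH]c2c1=O)c1cccnc1` gives 1.66%; the step of a number 29.3 percentage points lower from compound 1 to compound 2 (beyond the scatter) lies beyond the scatter. Compound 4 `O=C(Nn1c(-c2cccc([N+](=O)[O-])c2)nc2c(-c3ccc(Cl)cc3)n[nH]c2c1=O)c1ccccc1` differs from compound 1 in one place: phenyl in place of pyridin-3-yl on a carbonyl carbon. Within the data shown here, none of the measured steps touches this carbonyl carbon; each of them changes the group on the aromatic carbon instead, so no measured step bears on this change. With nothing to point either way, no step beyond the scatter is expected, and the estimated step is no change at the digits printed from compound 1 to compound 4 (within the scatter). Compound 4 is therefore expected to give 31%, with a range from 14% to 48%.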

Compound 4, a percentage reported as inhibition, at one concentration (the size of the read-out at that concentration, not a potency): 94.3%
Compound 4: the middle estimate sits 63.3 percentage points below what was measured; measured number outside the range, above it.
By their numbers in this assay, from the lowest: compound 2; then compounds 1 and 3 (each within the scatter of the next); then compound 4.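

On the carbonyl carbon, the group matters a great deal in this assay: phenyl in place of pyridin-3-yl gives a number 63.3 percentage points higher from compound 1 to compound 4 (beyond the scatter). The change replaces only a ring nitrogen with carbon, yet the step is larger than any seen among the changes on the aromatic carbon. No measurement at hand explains this jump.

Going by these compounds, whether phenyl gives the same gain with furan-2-yl or thiophen-2-yl on the aromatic carbon remains open. So does the outcome with a substituted phenyl, such as 4-methoxyphenyl, or a cyclohexyl ring on the carbonyl carbon.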